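The source may hold more compounds than are shown below. What is called first, only, known or untested is meant among the compounds shown, and "the series" means these compounds.

Measured so far:
compound 1 `O=C1NC(=O)/C(=C\c2ccc(OCC(=O)N3N=C(c4ccccc4)CC3c3ccccc3Cl)cc2)S1` — 1200 nM
compound 2 `O=C1NC(=O)/C(=C\c2ccc(OCC(=O)N3N=C(c4ccccc4)CC3c3ccc(C(F)(F)F)cc3)cc2)S1` — 1000 nM

In an assay on cells for inhibition of histone deacetylase 4 (Homo sapiens), read by fluorescence, with a stated time of 30 min (on this read-out higher numbers stand for weaker inhibition and lower numbers for stronger inhibition), compound 2 gives 1000 nM, and the other number, that of compound 1, sits within the scatter of it. Compound 3 `O=C1NC(=O)/C(=C\c2ccc(OCC(=O)N3N=C(c4ccccc4)CC3c3ccc(F)cc3)cc2)S1` differs from compound 2 by fluoro in place of trifluoromethyl on an aromatic carbon. Within the data shown here, the one measured step on this ring, a 1.2-fold lower number from compound 1 to compound 2 (0.08 log units; within the scatter), swapped one substituted phenyl for another without moving the number beyond the scatter. On that basis the step of a 1.1-fold higher number from compound 2 to compound 3 (0.04 log units; within the scatter) expected in this assay is of no size beyond the scatter, in either direction. The estimate for compound 3 is 1100 nM, with a range of 500 nM to 2500 nM.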

Compound 3, half-maximal inhibitory concentration: 1700 nM
Estimate against measurement, compound 3: 1.5-fold (0.19 log units) below, and the stated range covers the measured number.
By their numbers in this assay, from the lowest: compounds 2, 1 and 3 (each within the scatter of the next).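

In this assay, fluoro in place of trifluoromethyl on the aromatic carbon, para to a large group, gives a 1.7-fold higher number from compound 2 to compound 3 (0.23 log units; within the scatter), and 4-fluorophenyl in place of 2-chlorophenyl gives a 1.4-fold higher number from compound 1 to compound 3 (0.15 log units; within the scatter). All three substituted phenyls therefore lie within the scatter of one another, now including a pair that differs only in fluoro against trifluoromethyl at the same place. From the compounds shown here alone, whether an amine, a carboxylic acid or a longer alkyl chain at this aromatic carbon would give a step beyond the scatter remains open. No available evidence gives a reason for these small steps.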